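The compounds below may be only part of what the source reports. "The series", "measured", "known", "first", "only" and "open" are said of these compounds alone.

Compound 1 `OCCCCNCc1nc2c(OCC3CCCCC3)cccc2[nH]1`: 30000 nM
Compound 2 `OCC(NCc1nc2c(OCC3CCCCC3)cccc2[nH]1)c1ccccc1`: 20000 nM

The two measured compounds share the same core and differ only in the group carried on an amine nitrogen. In an assay on cells for inhibition of interleukin-5 receptor subunit alpha (Mus musculus), read by WST assay, with a stated time of 48 h, in the presence of a further agent that is not named here (a lower number here means a stronger inhibitor, a higher number a weaker inhibitor), compound 1 gives 30000 nM, and compound 2 gives 20000 nM. Going by the values given here, the single measured step is a 1.5-fold lower number from compound 1 to compound 2 (0.18 log units; within the scatter). Among the compounds with values here, compound 2 therefore has the lowest of the two numbers so far, but its only neighbour, compound 1, sits within the scatter, so the two cannot be ranked against each other.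

Compound 3 `COc1ccc(CNCc2nc3c(OCC4CCCCC4)cccc3[nH]2)cc1` has not yet been measured. It differs from compound 2 as follows: 4-methoxybenzyl in place of 2-hydroxy-1-phenylethyl on an amine nitrogen. Within the data shown here, only one measured step bears on a swap of the group on this amine nitrogen, namely a 1.5-fold lower number from compound 1 to compound 2 (0.18 log units; within the scatter), and that step stayed within the scatter. On that basis no step beyond the scatter is expected in this assay from compound 2 to compound 3, in either direction. Compound 3 is therefore expected to give about 20000 nM, with a plausible range from 7000 nM to 60000 nM, which corresponds to an expected step of no change at the digits printed from compound 2 to compound 3 (within the scatter).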

Compound 3, half-maximal inhibitory concentration: > 30000 nM
Compound 3 gave a limit, no number; the forecaster's own chance of this, stated with the estimate: 25%; middle value at least 1.5-fold (0.17 log units) from the limit.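

In this assay compound 3 gives > 30000 nM, which is a limit of the assay and not a number. The swap on this amine nitrogen keeps the heavy-atom count and the aromatic ring but goes from 1 hydrogen-bond donor to 0 hydrogen-bond donors, and the outcome is an at least 1.5-fold higher number from compound 2 to compound 3 (0.17 log units; that floor lies within the scatter), so only a floor for the step is known, and that floor does not by itself show a real change. This adds one thing to the earlier pair: a 4-methoxybenzyl group here, with no hydrogen-bond donor, brings a number no lower from compound 1 to compound 3 (the limit leaves the size open) and the size of that step cannot be read because the reading ends in a limit: the limit of > 30000 nM in this assay, at which 1 of the 3 values shown sits.

The compounds shown cannot tell whether the hydroxyl group in compound 1 and compound 2 matters at all, since the true value of compound 3 is unknown. Also open, on these data alone, is whether a carboxylic acid, a second amine or a longer chain on this nitrogen would give a clearly lower number than the values seen so far on the shared core.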